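Solubility notes on a shared-core series, compounds 1 to 4

The source may report more compounds than this note shows. Statements on the series, on what has been measured and on what is new or still open speak of the compounds shown alone.

Measured so far, each in a physicochemical assay for solubility; a higher number here means a more soluble compound, a lower number a less soluble compound:
compound 1 `O=C(O)c1ccc(C(=O)/C(=C\c2ccc([N+](=O)[O-])c(F)c2)SCc2ccc(Br)cc2)cc1`: compound 1 gives < 1000 ug/mL, a limit of the assay.
compound 2 `O=C(O)c1ccc(C(=O)/C(=C\c2ccc(O)c(Br)c2)SCc2ccc(Br)cc2)cc1`: compound 2 gives < 1000 ug/mL, a limit of the assay.
compound 3 `COc1cc(/C=C(/SCc2ccc(Br)cc2)C(=O)c2ccc(C(=O)O)cc2)ccc1F`: compound 3 gives < 1000 ug/mL, a limit of the assay.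

Compound 3 therefore stands only at a limit, not at a number, as do the other two; all three sit together (the limit of < 1000 ug/mL in this assay, at which 3 of the 3 values shown sit). The steps a step that the two limits leave unreadable from compound 1 to compound 2, a step that the two limits leave unreadable from compound 1 to compound 3 and a step that the two limits leave unreadable from compound 2 to compound 3 are all unreadable for the same reason. Compound 4 `O=C(O)c1ccc(C(=O)/C(=C\c2ccc(O)c([N+](=O)[O-])c2)SCc2ccc(Br)cc2)cc1` differs from compound 3 in one place: 4-hydroxy-3-nitrophenyl in place of 4-fluoro-3-methoxyphenyl on a double-bonded chain carbon bound to a double-bonded chain carbon. The step from compound 2 to compound 3 touches the same position but gives no readable size, so no direction beyond the scatter can be expected in this assay. Compound 4 is expected to remain at the limit, with an estimated 300 ug/mL (50 ug/mL to 1000 ug/mL), an expected step that the limit leaves unreadable from compound 3 to compound 4.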

Compound 4, solubility: < 1000 ug/mL
Compound 4: a limit, no number; the forecaster's own chance of this, stated with the estimate: 80%; the middle value is on the limit's open side.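

In this assay compound 4 gives < 1000 ug/mL, a limit of the assay, and no step among compound 1, compound 2, compound 3 and compound 4 can be read: the limit of < 1000 ug/mL in this assay, at which 4 of the 4 values shown sit.

The compounds shown leave open where each one's solubility actually lies and whether any of these changes alters it.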